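Working notes: adding dimethylamino to compound 2

The source may report more compounds than this note shows. Statements on the series, on what has been measured and on what is new or still open speak of the compounds shown alone.

Measured so far in a physicochemical assay for lipophilicity, at pH 7.4 (on this read-out lower numbers stand for lower lipophilicity and higher numbers for higher lipophilicity), of the series:
- compound 1 `Oc1c(-c2nnc(Cc3ccc(Cl)cc3)[nH]2)ncc2cccnc12` – 4.1
- compound 2 `Cc1n[nH]c(-c2ncc3cccnc3c2O)n1` – 0.73
- compound 3 `O=C1CCCN1Cc1n[nH]c(-c2ncc3cccnc3c2O)n1` – "not determined" (no result reported)

Compound 2 holds the lower of the two numbers, with 0.73 against compound 1 at 4.1, a gap beyond the scatter. Compound 3 offers no number for comparison. Compound 4 `Cc1n[nH]c(-c2ncc3c(N(C)C)ccnc3c2O)n1` differs from compound 2 in one place (dimethylamino in place of hydrogen on an aromatic carbon), with dimethylamino in place of hydrogen on an aromatic carbon, opposite the ring nitrogen. Going by the values given here, no measured pair shows this change, so the expectation is loose. A modest rise in this assay is expected, estimated as a number 0.37 log units higher from compound 2 to compound 4 (beyond the scatter) for this change alone. In this assay compound 4 is expected at 1.1, with an estimated range of 0.5 to 1.8 as the likely span.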

Compound 4, distribution coefficient: -0.6
Beside the measured number, compound 4's estimate is 1.70 log units above it; the measured number lies below the stated range.
By their numbers in this assay, from the lowest: compound 4; then compound 2; then compound 1.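

In this assay, going by these compounds alone, dimethylamino in place of hydrogen on an aromatic carbon, opposite the ring nitrogen, gives a number 1.33 log units lower from compound 2 to compound 4 (beyond the scatter), the only step so far between measured compounds that differ in one place. The number falls even though 3 heavy atoms enter at this position. Nothing available explains this fall.

The compounds shown leave open whether the fall is specific to dimethylamino or also occurs with another group on the same aromatic carbon, such as methylamino, methoxy or morpholine. A single step also cannot show whether the same change would behave alike with a different substituent in place of the methyl of compound 2.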